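Replacing difluoromethyl with cyano in a weakly cytotoxic compound

A few compounds are considered here, and "the series" means these few. Any claim that something is new, unique, unknown or untested is made for them only; others in the source may bear on it.

Going by the values given here, in a functional assay on HT cells (Homo sapiens) for cytotoxicity, read by CCK-8 assay, with a stated time of 72 h (on this read-out higher numbers stand for weaker inhibition and lower numbers for stronger inhibition), compound 1 `Cn1cc(NC(=O)c2cnc3ccc(N[C@@H]4CCCNC4)nn23)c(C(F)F)n1` gives 40100 nM, the only exact number measured so far. Compound 2 `Cn1cc(NC(=O)c2cnc3ccc(NCCN)nn23)c(C(F)F)n1` reads > 50000 nM, and this is a limit of the assay, not a number.

The next compound, compound 3 `Cn1cc(NC(=O)c2cnc3ccc(N[C@@H]4CCCNC4)nn23)c(C#N)n1`, keeps the core of compound 1 and its piperidin-3-yl group. It carries cyano in place of difluoromethyl on an aromatic carbon of the five-membered aromatic ring with 2 nitrogen: cyano in place of difluoromethyl on an aromatic carbon.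

Among the compounds with values here, only one measured step is available, an at least 1.2-fold higher number from compound 1 to compound 2 (0.09 log units; that floor lies within the scatter). It lies within the scatter, and it concerns the group on a nitrogen rather than this aromatic carbon. Within the data shown here, it therefore offers only weak guidance, and no measured step shows what this swap does. With nothing pointing either way, no step beyond the scatter is expected, and no direction is predicted. The estimated step is a 1.0-fold lower number from compound 1 to compound 3 (0.00 log units; within the scatter). Compound 3 might also be expected to reach (the limit of > 50000 nM in this assay, at which 1 of the 2 values shown sits). For compound 3, the expected value is 40000 nM, with an estimated range from 15000 nM to 60000 nM.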

Compound 3, half-maximal inhibitory concentration: > 50000 nM
Compound 3 ended at the assay's limit; the forecaster's own chance of this, stated with the estimate: 40%; middle value at least 1.2-fold (0.09 log units) from the limit.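

In this assay, going by these compounds alone, this is the first measured change on the aromatic carbon of the five-membered ring, since the earlier step concerned the group on a nitrogen. Cyano in place of difluoromethyl gives an at least 1.2-fold higher number from compound 1 to compound 3 (0.09 log units; that floor lies within the scatter), so the swap brings no sign of stronger inhibition, but the floor alone cannot separate a real weakening from ordinary scatter, and the true size of the step is unknown. Exact readings are now the exception in this small set, which leaves compound 1 as the only compound with a number that can anchor a comparison: the limit of > 50000 nM in this assay, at which 2 of the 3 values shown sit.

Still open, going by these compounds, is how far past the limit compound 3 lies, and so whether cyano and difluoromethyl differ at all on this carbon. Also open, on these data alone, is whether another group at this place, such as trifluoromethyl, a chlorine atom or a carboxylic acid, would move the number in either direction, or whether the position can only hold the reading near the limit in this weakly cytotoxic series.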